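This account rests on a few compounds, and the source may have more. Where it says the series, first, only, none or still open, it means among the compounds named here.

Compound 1 `O=C(Nc1ccccc1C(F)(F)F)C1CCc2ccccc2N1C(=O)c1ccccc1` was examined in a functional assay on NUGC-3 cells (Homo sapiens) for cytotoxicity, read by sulforhodamine B assay, with a stated time of 72 h (on this read-out lower numbers stand for stronger inhibition of growth and higher numbers for weaker inhibition of growth), where compound 1 gives 8120 nM. Among the three compounds measured so far this is the highest number. Among the compounds with values here, compound 2 `O=C(Nc1ccccc1O)C1CCc2ccccc2N1C(=O)c1ccccc1` gives 3780 nM in this assay, and the only single-point step available, a 2.1-fold lower number from compound 1 to compound 2 (0.33 log units; beyond the scatter), shows that a change at an aromatic carbon shifts the read-out by a modest amount. Within the data shown here, compound 3 `CCCCCCCCC(=O)N1c2ccccc2CCC1C(=O)Nc1cc(C(F)(F)F)cc(C(F)(F)F)c1` gives 2230 nM; it differs from compound 1 in more than one place, so its value shows only that a nonanoyl group on the amide-type nitrogen in a ring, together with a different aromatic substitution, sits lower than compound 1. Compound 4 `CC(=O)N1c2ccccc2CCC1C(=O)Nc1ccccc1C(F)(F)F` has not yet been measured. It differs from compound 1 as follows: methyl in place of phenyl on a carbonyl carbon. Among the measured compounds shown here, no measured step alters only the group on the carbonyl carbon attached to the amide-type nitrogen in a ring, so there is no direct guide. The step of a 1.1-fold higher number from compound 1 to compound 4 (0.04 log units; within the scatter) is therefore expected to stay within the scatter. Compound 4 is estimated at 9000 nM, with a range from 3000 nM to 30000 nM.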

Compound 4, concentration for 50% growth inhibition: > 80000 nM
Compound 4: no number, only a limit; the forecaster's own chance of this, stated with the estimate: 10%; middle value at least 8.8-fold (0.94 log units) from the limit.
By their numbers in this assay, from the lowest: compounds 3 and 2 (each within the scatter of the next); then compound 1. At a limit, above all of these: compound 4.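

Replacing the benzoyl group with acetyl, on a carbonyl carbon whose other neighbour is the amide-type nitrogen in a ring, gives an at least 9.8-fold higher number from compound 1 to compound 4 (0.99 log units; beyond the scatter) in this assay. Within the data shown here, this is the first single-place change at this carbonyl carbon, and it shows that growth inhibition depends on the group held there, whereas the earlier step showed only a change at an aromatic carbon. The result for compound 4 is a limit and not a number: the limit of > 80000 nM in this assay, at which 1 of the 4 values shown sits.

Going by these compounds, it remains open whether the aromatic ring of the phenyl group matters or simply the carbons it brings, which a cyclohexyl group or a longer chain in the same place, on the otherwise unchanged compound 1, would separate. Compound 3 carries a nonanoyl group but also differs in its aromatic substitution, so it cannot settle this.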